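Compound 2 to compound 3: losing the hydroxymethyl

The compounds below may be only part of what the source reports. "The series", "measured", "known", "first", "only" and "open" are said of these compounds alone.

Values in a toxicity assay on HEK-293T cells (Homo sapiens) for cytotoxicity, read by MTT assay, with a stated time of 72 h; on this read-out higher numbers stand for weaker inhibition and lower numbers for stronger inhibition:
- compound 1 `O=C1c2c[n+]([O-])c3ccccc3c2C(=O)c2c1c1ccccc1n2Cc1cn(CC(O)CO)nn1`: 760 nM
- compound 2 `CC1(C)O[C@@H](CO)[C@H](Cn2cc(Cn3c4c(c5ccccc53)C(=O)c3c[n+]([O-])c5ccccc5c3C4=O)nn2)O1`: 120 nM

Going by the values given here, compound 2 holds the lower of the two numbers so far, on the side of stronger inhibition. The next structure, compound 3 `CC1(C)OC[C@H](Cn2cc(Cn3c4c(c5ccccc53)C(=O)c3c[n+]([O-])c5ccccc5c3C4=O)nn2)O1`, carries a single change: hydrogen in place of hydroxymethyl on a saturated ring carbon. In words, this is hydrogen in place of hydroxymethyl on a saturated ring carbon. Among the compounds with values here, the only measured step that bears on it is a 6.3-fold lower number from compound 1 to compound 2 (0.80 log units; beyond the scatter), a modest step within the same substituent. Within the data shown here, that step replaced 1,2-dihydroxyethyl with 5-(hydroxymethyl)-2,2-dimethyl-1,3-dioxolan-4-yl, which does not isolate the hydroxymethyl, and no measured pair does. Compound 3 keeps the 2,2-dimethyl-1,3-dioxolan-4-yl unit, so it is expected to stay near compound 2 at 120 nM rather than return toward compound 1 at 760 nM. In this assay the expected step is a 1.2-fold lower number from compound 2 to compound 3 (0.08 log units; within the scatter), an estimate that does not reach beyond the scatter. For compound 3 the estimated value is 100 nM, with an expected range of 35 nM to 300 nM.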

Compound 3, half-maximal inhibitory concentration: 100 nM
For compound 3 middle estimate and measured number coincide at the digits printed, within the range that was stated.
By their numbers in this assay, from the lowest: compounds 3 and 2 (each within the scatter of the next); then compound 1.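

In this assay, hydrogen in place of hydroxymethyl on the saturated ring carbon gives a 1.2-fold lower number from compound 2 to compound 3 (0.08 log units; within the scatter), so compounds 2 and 3 cannot be told apart and the hydroxymethyl shows no measurable contribution at this position. Compound 3 also isolates the 2,2-dimethyl-1,3-dioxolan-4-yl unit without that hydroxymethyl: 2,2-dimethyl-1,3-dioxolan-4-yl in place of 1,2-dihydroxyethyl gives a 7.6-fold lower number from compound 1 to compound 3 (0.88 log units; beyond the scatter), so the separation from compound 1 persists with no hydroxymethyl on the ring. No supporting measurement is available to account for either step.

Open, on these data alone, is whether other groups on this saturated ring carbon, such as an amine, a carboxylic acid or a longer chain, would stay level with compounds 2 and 3 or move away from them. The compounds shown also do not separate the contribution of the closed five-membered ring from that of its two methyl groups, so a 1,3-dioxolan-4-yl ring without those methyl groups would be needed to assign the step from compound 1.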